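Working notes: furan-2-yl in place of 1-methyl-1H-pyrrol-2-yl

The compounds below may be only part of what the source reports. "The series", "measured", "known", "first", "only" and "open" are said of these compounds alone.

Measured in a functional assay on Raji cells (Homo sapiens) for cytotoxicity, with a stated time of 72 h; on this read-out higher numbers stand for weaker inhibition and lower numbers for stronger inhibition:
Compound 1 (`CCOC(=O)/C=C/C=C/C=C/C=C/C=C/c1ccc[nH]1`): > 10000 nM (a limit)
Compound 2 (`CCOC(=O)/C=C/C=C/C=C/C=C/c1cccn1C`): > 10000 nM (a limit)

Compound 2 has no numerical value, and its > 10000 nM is a limit of the assay. Among the compounds with values here, the series so far stands at the limit of > 10000 nM in this assay, at which 2 of the 2 values shown sit, and offers no measured step. Compound 3 (`CCOC(=O)/C=C/C=C/C=C/C=C/c1ccco1`) carries furan-2-yl in place of 1-methyl-1H-pyrrol-2-yl on a double-bonded chain carbon bound to a double-bonded chain carbon, counted as furan-2-yl in place of 1-methyl-1H-pyrrol-2-yl on a double-bonded chain carbon bound to a double-bonded chain carbon for this change. In this assay no step beyond the scatter is expected, and no direction is favoured. The estimated step that the limit leaves unreadable from compound 2 to compound 3 is expected to stay within the scatter. Compound 3 is expected at 14000 nM, with an estimated range of 5000 nM to 30000 nM.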

Compound 3, half-maximal inhibitory concentration: > 10000 nM
Compound 3 ended at the assay's limit (the forecaster's own chance of this, stated with the estimate: 85%); the middle value lies beyond the limit too.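

No step can be read from compound 2 to compound 3, as both stand at a limit in this assay: the limit of > 10000 nM in this assay, at which 3 of the 3 values shown sit.

The compounds shown leave open whether any change to the shared core gives a numerical value in this assay.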